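This account rests on a few compounds, and the source may have more. Where it says the series, first, only, none or still open, it means among the compounds named here.

Measured compounds:
- compound 1, `CC(=NNC(=S)Nc1ccccc1)c1ccccn1`: 6.8 nM in a functional assay on T98G cells (Homo sapiens) for cytotoxicity, read by MTT assay, with a stated time of 48 h; a higher number here means a weaker inhibitor, a lower number a stronger inhibitor
- compound 2, `C/C(=N/NC(=S)Nc1cccc(F)c1)c1ccccn1`: 12 nM in this assay
- compound 3, `CC(=NNC(=S)Nc1cccc([N+](=O)[O-])c1)c1ccccn1`: 140 nM in this assay

Among the three numbers, compound 3 stands highest; its nearest neighbour is compound 2 and its furthest is compound 1, both well outside the usual scatter. Going by the values given here, the only single-point step among the measured compounds is a 21-fold higher number from compound 1 to compound 3 (1.31 log units; beyond the scatter), which shows that putting the nitro group onto the ring costs a great deal of potency.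

Compound 4, `CC(=NNC(=S)Nc1cccc(F)c1)c1ccccn1`, reverses part of that picture. Relative to compound 3 the change is fluoro in place of nitro on an aromatic carbon. Among the compounds with values here, no measured step covers a direct exchange of nitro for fluoro, but compound 2 carries a fluoro on the same ring and gives 12 nM, while compound 1 with plain hydrogen gives 6.8 nM. Compound 4 is therefore expected to fall back toward those two, with a large downward step a 12-fold lower number from compound 3 to compound 4 (1.07 log units; beyond the scatter) in this assay. The estimate for compound 4 is 12 nM, with a likely range from 5 nM to 30 nM, resting on the value of compound 2.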

Compound 4, half-maximal inhibitory concentration: 12 nM
The estimate for compound 4 equals the measured number at the digits printed, within the range that was stated.
By their numbers in this assay, from the lowest: compounds 1, 2 and 4 (each within the scatter of the next); then compound 3.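

In this assay, exchanging nitro for fluoro on this aromatic carbon recovers most of what the nitro group cost, with a 12-fold lower number from compound 3 to compound 4 (1.07 log units; beyond the scatter), so at this position the penalty goes with nitro and not with every replacement of hydrogen. Fluoro in place of hydrogen is tolerated here, with a 1.8-fold higher number from compound 1 to compound 4 (0.25 log units; within the scatter), which means this position can carry a fluoro without a change that stands out from ordinary assay variation. Going by these compounds alone, the drawing of the double bond does not separate the two fluoro compounds either, with no change at the digits printed from compound 2 to compound 4 (within the scatter), and only one feature distinguishes that pair: the fact that one of compounds 2 and 4 is drawn with a defined configuration and the other without, at the place where they differ.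

Only hydrogen, fluoro and nitro are shown at this position, so it remains open how a chloro, a methoxy, an amine or a carboxylic acid there would read in this assay. Within the data shown here, with nitro as the only costly group, the compounds cannot show which feature of nitro carries the loss, nor whether compound 4 is actually the same double-bond form drawn for compound 2.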